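The compounds below may be only part of what the source reports. "The series", "measured", "known", "first", "only" and "open" are said of these compounds alone.

Working notes on the series in a functional assay on KB cells (Homo sapiens) for antiproliferative activity, read by sulforhodamine B assay, with a stated time of 3 days; a lower number here means that less compound is needed, a higher number that more compound is needed for the effect.

Going by the values given here, three analogues sharing one core have numbers so far. Compound 1 `CCCCc1ccc(-c2cc(=O)c3c(o2)C(CC)(CC)C(=O)C(CC)=C3O)cc1` gives 111 uM. Compound 2 `CCC1=C(O)c2c(oc(-c3cccc(C)c3)cc2=O)C(CC)(CC)C1=O` gives 49.7 uM. Compound 3 `CCC1=C(O)c2c(oc(-c3ccccc3C(F)(F)F)cc2=O)C(CC)(CC)C1=O` gives 45.6 uM. Within these three, compound 2 stands second highest; its number and that of compound 3 lie within the usual scatter of this assay, so no order between them is read. Among the compounds with values here, compound 1 lies beyond the scatter from compound 2, with the higher number, and no single-change step between any two measured compounds is available.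

The next compound, compound 4 `CCC1=C(O)c2c(oc(-c3ccc(OC)c(F)c3)cc2=O)C(CC)(CC)C1=O`, keeps the core of compound 2 and changes only the aryl group: 3-fluoro-4-methoxyphenyl in place of 3-methylphenyl on an aromatic carbon

Within the data shown here, no measured step informs this exchange, and the three numbers so far span a narrow band. The step from compound 2 to compound 4 is expected to be small, most likely none beyond the scatter, with a slight lean toward a lower number: a 1.2-fold lower number from compound 2 to compound 4 (0.07 log units; within the scatter). Compound 4 is therefore estimated at 42 uM, in a range of 18 uM to 100 uM.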

Compound 4, concentration for half-maximal effect: 26.7 uM
The estimate for compound 4 lay 1.6-fold (0.20 log units) above the measured number; the range from low to high includes it.
By their numbers in this assay, from the lowest: compounds 4, 3 and 2 (each within the scatter of the next); then compound 1.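

At the aromatic carbon next to the ring oxygen, 3-fluoro-4-methoxyphenyl in place of 3-methylphenyl gives in this assay a 1.9-fold lower number from compound 2 to compound 4 (0.27 log units; within the scatter). Going by these compounds alone, this is the first single-change reading at this position, which the earlier compounds could not supply: a larger aryl group carrying a hydrogen-bond acceptor leaves the number within the scatter of the one for the 3-methylphenyl group. No measured property is at hand that would explain this small step.

The compounds shown do not separate the contribution of the fluorine from that of the methoxy group, as the two enter together and the methyl group leaves in the same step. Also open, on these data alone, is how this position responds to an amine or a carboxylic acid on the aryl ring, or to a longer alkyl chain in place of the aryl group.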